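The source may report more compounds than this note shows. Statements on the series, on what has been measured and on what is new or still open speak of the compounds shown alone.

Compound 1 `C=CC(=O)Nc1cc(Nc2nccc(NC(=O)c3cccc4ccccc34)n2)c(OC)cc1N1CCN(C)CC1`: 6770 nM
Compound 2 `C=CC(=O)Nc1cc(Nc2nccc(NC(=O)c3ccccc3)n2)c(OC)cc1N(C)CCN(C)C`: 1740 nM
Compound 3 `C=CC(=O)Nc1cc(Nc2nccc(NC(=O)c3ccc(C(F)(F)F)cc3)n2)c(OC)cc1N(C)CCN(C)C`: 9880 nM

In a functional assay on A549 cells (Homo sapiens) for antiproliferative activity, read by MTT assay, with a stated time of 72 h (on this read-out higher numbers stand for weaker inhibition and lower numbers for stronger inhibition), compound 1 lies within the scatter of compound 3. Compound 1 has a clearly higher number than compound 2, a gap beyond the scatter, and compound 2 is the most potent of the three.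

The next compound is compound 4 `C=CC(=O)Nc1cc(Nc2nccc(NC(=O)c3ccccc3)n2)c(OC)cc1N1CCN(C)CC1`, which has phenyl in place of naphthalen-1-yl on a carbonyl carbon. Within the data shown here, no measured step makes this exact change. The nearest evidence is a 5.7-fold higher number from compound 2 to compound 3 (0.75 log units; beyond the scatter), where trifluoromethyl replaces hydrogen on an aromatic carbon. Read backwards, that modest step points towards a lower number for the unsubstituted phenyl. Compound 2 at 1740 nM shares the benzoyl group of compound 4 but differs from it elsewhere, so it is only a loose guide.

A modest fall, beyond the scatter, is therefore expected in this assay. The expected step is a 2.7-fold lower number from compound 1 to compound 4 (0.43 log units; beyond the scatter). For compound 4 the estimated value is 2500 nM, with an expected range of 900 nM to 7000 nM.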

Compound 4, half-maximal inhibitory concentration: 5970 nM
The estimate for compound 4 lay 2.4-fold (0.38 log units) below the measured number; the measured number falls inside the stated range.
By their numbers in this assay, from the lowest: compound 2; then compounds 4, 1 and 3 (each within the scatter of the next).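

In this assay, the change from (naphthalen-1-yl)carbonyl to benzoyl gives a 1.1-fold lower number from compound 1 to compound 4 (0.05 log units; within the scatter), so at this carbonyl carbon the naphthalen-1-yl and phenyl groups are not separated on this read-out. Among these compounds, with benzoyl held constant, 4-methylpiperazin-1-yl in place of (2-(dimethylamino)ethyl)(methyl)amino gives a 3.4-fold higher number from compound 2 to compound 4 (0.54 log units; beyond the scatter), which isolates that aromatic-carbon position for the first time and shows a step there beyond the scatter. No evidence on the origin of either step is available.

Whether trifluoromethyl on the benzoyl group would read the same with 4-methylpiperazin-1-yl remains open, since it is shown only with (2-(dimethylamino)ethyl)(methyl)amino. Also open, from the compounds shown here alone, is how a carboxylic acid on the benzoyl group, or morpholin-4-yl in place of 4-methylpiperazin-1-yl, would compare.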